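The source may report more compounds than this note shows. Statements on the series, on what has been measured and on what is new or still open speak of the compounds shown alone.

Compound 1 `Cn1c(-c2ccc(NC(=O)CCl)cc2)nc(-c2ccccc2)c1-c1ccccc1`: 7.2%
Compound 2 `Cn1c(-c2ccc(NC(=O)CSc3nc4ccccc4o3)cc2)nc(-c2ccccc2)c1-c1ccccc1`: 24.8%

In a functional assay on HT-29 cells (Homo sapiens) for cytotoxicity, read by MTT assay, with a stated time of 24 h, tested at 0.64 ug/mL (on this read-out higher numbers stand for a stronger effect at the one concentration tested and lower numbers for a weaker effect), compound 2 stands highest of the two numbers, above compound 1 by a number 17.6 percentage points higher from compound 1 to compound 2 (beyond the scatter). Compound 3 `Cn1c(-c2ccc(NC(=O)CSc3nc4cc(Cl)ccc4o3)cc2)nc(-c2ccccc2)c1-c1ccccc1` differs from compound 2 by chloro in place of hydrogen on an aromatic carbon. Among the measured compounds shown here, no measured step touches this place: the one known step, from compound 1 to compound 2, changes a different part of the chain and gives no guide to a chloro added on the ring. With nothing pointing either way, compound 3 is expected to show a step of a number 3.2 percentage points higher from compound 2 to compound 3 (within the scatter), inside the usual scatter. Compound 3 is therefore estimated at 28%, with a range from 10% to 50%.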

Compound 3, a percentage reported as activity, at one concentration (the size of the read-out at that concentration, not a potency): 11.9%
Compound 3: the middle estimate sits 16.1 percentage points above what was measured; the range from low to high includes it.
By their numbers in this assay, from the lowest: compounds 1 and 3 (each within the scatter of the next); then compound 2.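

With one chloro added to the 1,3-benzoxazol-2-yl group, this assay shows a number 12.9 percentage points lower from compound 2 to compound 3 (beyond the scatter) and so reveals that this aromatic carbon responds to substitution, which the earlier change on the chain could not show. The gain that came with the (1,3-benzoxazol-2-yl)sulfanyl group is not kept, since the comparison with the chloroacetamide gives a number 4.7 percentage points higher from compound 1 to compound 3 (within the scatter) as its step. Open, as far as these compounds go, is whether a fluoro, a methoxy or an amine on this carbon would also lower the number, and whether a chloro on another carbon of this ring would do the same. Nothing available explains why the chloro acts this way.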